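Notes on the cyclopentyl to isopropyl step

A few compounds are considered here, and "the series" means these few. Any claim that something is new, unique, unknown or untested is made for them only; others in the source may bear on it.

Compound 1 `Nc1ncnc2c1c(C(=O)c1cccc(NC(=O)Nc3ccc(Cl)cc3)c1)cn2C1CCCC1` gives 0.7 in an ADME assay on microsomes from liver (Rattus norvegicus) for metabolic stability; a higher number here means that the liver removes a larger share of the compound in one pass, a lower number that the liver removes a smaller share; compound 2 `COc1ccc(C)cc1NC(=O)Nc1cccc(C(=O)c2cn(C3CCCC3)c3ncnc(N)c23)c1` gives 0.69, the step a number 0.010 lower from compound 1 to compound 2 (within the scatter) being the only one measured. Compound 3 `CC(C)n1cc(C(=O)c2cccc(NC(=O)Nc3ccc(Cl)cc3)c2)c2c(N)ncnc21` differs from compound 1 by isopropyl in place of cyclopentyl on an aromatic nitrogen. Going by the values given here, no measured step touches this aromatic nitrogen; the single step a number 0.010 lower from compound 1 to compound 2 (within the scatter) concerns the group on an amide-type nitrogen and so gives no direct guide. Compound 3 is therefore expected to stay near compound 1, the estimated step being a number 0.050 lower from compound 1 to compound 3 (within the scatter), not beyond the scatter. The estimated value for compound 3 is 0.65, with a range from 0.5 to 0.8.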

Compound 3, hepatic extraction ratio: 0.52
For compound 3 the middle estimate is 0.13 above the measured one; low and high end bracket the measured number.
By their numbers in this assay, from the lowest: compound 3; then compounds 2 and 1 (each within the scatter of the next).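

Isopropyl in place of cyclopentyl on an aromatic nitrogen gives a number 0.18 lower from compound 1 to compound 3 (beyond the scatter) in this assay. Going by these compounds alone, this is the first single change to pass the scatter, whereas the change on the amide-type nitrogen, a number 0.010 lower from compound 1 to compound 2 (within the scatter), does not, so of these two places only the aromatic nitrogen shows a response. Nothing available bears on the reason for this step.

Going by these compounds, whether methyl or a hydroxyethyl chain on this aromatic nitrogen would lie lower still remains open. So does whether the step carries over when 2-methoxy-5-methylphenyl sits on the amide-type nitrogen.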